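Replacing 4-Nitrophenyl with 3-Hydroxybenzyl in Compound 3

A few compounds are considered here, and "the series" means these few. Any claim that something is new, unique, unknown or untested is made for them only; others in the source may bear on it.

In a functional assay on HL-60 cells (Homo sapiens) for inhibition, read by CCK-8 assay, with a stated time of 48 h (on this read-out lower numbers stand for stronger inhibition and higher numbers for weaker inhibition), compound 1 `O=S(=O)(NCCNC(=S)Nc1cccc(Cl)c1)c1ccc(-c2ccccc2OCc2cccc(O)c2)s1` gives 1800 nM. Going by these compounds, compound 3 `COc1ccc(NC(=O)NCCNS(=O)(=O)c2ccc(-c3ccccc3Oc3ccc([N+](=O)[O-])cc3)s2)cc1` reaches only a limit, > 50000 nM, so its true position on the scale is unknown. Compound 4 `COc1ccc(NC(=O)NCCNS(=O)(=O)c2ccc(-c3ccccc3OCc3cccc(O)c3)s2)cc1` differs from it by 3-hydroxybenzyl in place of 4-nitrophenyl on an oxygen on an aromatic ring. Within the data shown here, no measured step tests this swap directly. Compound 1 and compound 2 `Cc1cc(C)cc(NC(=O)NCCNS(=O)(=O)c2ccc(-c3ccccc3OCc3cccc(O)c3)s2)c1` both carry 3-hydroxybenzyl, yet an at least 11-fold higher number from compound 1 to compound 2 (1.04 log units; beyond the scatter) shows that a change on an amine nitrogen alone is large. Sharing the urea of compound 4, compound 2 also reaches only a limit, > 20000 nM. A modest gain is therefore expected, with an at least 3.3-fold lower number from compound 3 to compound 4 (0.52 log units; beyond the scatter) as the estimated step towards stronger inhibition. Compound 4 is estimated at 15000 nM, with an expected range of 5000 nM to 45000 nM.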

Compound 4, half-maximal inhibitory concentration: > 20000 nM
Compound 4 ended at the assay's limit; the forecaster's own chance of this, stated with the estimate: 55%; middle value at least 1.3-fold (0.12 log units) away from the limit.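

Compound 4 stops at a limit, the same one as compound 2: the limit of > 20000 nM in this assay, at which 2 of the 4 values shown sit. The steps to compound 4 from compound 3 and from compound 2 cannot be read, so neither 3-hydroxybenzyl in place of 4-nitrophenyl nor 4-methoxyphenyl in place of 3,5-dimethylphenyl shows a measurable gain. Carrying 3-hydroxybenzyl is thus not enough on its own, as the change on the amine nitrogen gives an at least 11-fold higher number from compound 1 to compound 4 (1.04 log units; beyond the scatter).

Going by these compounds, the true strengths of compound 2, compound 3 and compound 4 stay open. So does whether a carboxylic acid in place of the hydroxyl of 3-hydroxybenzyl would change the result.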